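Replacing a fluoro on compound 1 with hydrogen

This account rests on a few compounds, and the source may have more. Where it says the series, first, only, none or still open, it means among the compounds named here.

In a functional assay on NCI-H460 cells (Homo sapiens) for antiproliferative activity, read by MTT assay, with a stated time of 72 h (a higher number here means a weaker inhibitor, a lower number a stronger inhibitor), compound 1 (`CC(C)(O)COc1ccc2c(Oc3ccc(Nc4nccc5[nH]cc(-c6ccc(F)cc6)c(=O)c45)cc3F)ccnc2c1`) gives 3200 nM and compound 2 (`COC(C)(C)COc1ccc2c(Oc3ccc(Nc4nccc5[nH]cc(-c6ccc(F)cc6)c(=O)c45)cc3F)ccnc2c1`) gives 4400 nM as its value. Among the measured compounds shown here, these are the only two measured compounds, and they lie within the scatter of each other, so compound 1 does not stand apart. For the measured compounds named here, the one measured step, a 1.4-fold higher number from compound 1 to compound 2 (0.14 log units; within the scatter), places methyl in place of hydrogen on an oxygen on a saturated carbon. Compound 3 (`CC(C)(O)COc1ccc2c(Oc3ccc(Nc4nccc5[nH]cc(-c6ccccc6)c(=O)c45)cc3F)ccnc2c1`) differs from compound 1 in another way: hydrogen in place of fluoro on an aromatic carbon, which is hydrogen in place of fluoro on an aromatic carbon, turning 4-fluorophenyl into phenyl. Going by the values given here, no measured step tests this change directly, and the methyl step offers only weak guidance. No shift beyond the scatter is therefore expected in this assay, in either direction. The estimated step is a 1.1-fold higher number from compound 1 to compound 3 (0.04 log units; within the scatter) and so stays within the scatter. For compound 3 the estimate is 3500 nM, with an expected range from 1500 nM to 8000 nM in repeat measurements.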

Compound 3, half-maximal inhibitory concentration: 3600 nM
For compound 3 the middle estimate is 1.0-fold (0.01 log units) below the measured one; the range from low to high includes it.
By their numbers in this assay, from the lowest: compounds 1, 3 and 2 (each within the scatter of the next).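

In this assay, among the compounds shown here, the change from 4-fluorophenyl to phenyl gives a 1.1-fold higher number from compound 1 to compound 3 (0.05 log units; within the scatter) and so provides the first direct reading at this position. Taking away this single fluoro, on an aromatic carbon para to a large group, leaves the number within the scatter, so in this pair the fluoro is not needed to keep the value at this level. The earlier step changed a different place and could say nothing about this ring, and no measurement shown here explains the lack of a clear shift.

This position therefore rests on one pair, and that pair compares only fluoro with hydrogen. As far as these compounds go, how a larger group in the same place, such as methoxy, an amine or a carboxylic acid, would read in this assay stays open.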